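The source may report more compounds than this note shows. Statements on the series, on what has been measured and on what is new or still open speak of the compounds shown alone.

Measured compounds:

compound 1 `CC1=C(C(=O)OC(C)C)C(c2ccoc2)NC(=O)N1C`: 37%
compound 2 `CC1=C(C(=O)OC(C)(C)C)C(c2ccoc2)NC(=O)N1C`: 16%
compound 3 `CCNC(=O)C1=C(C)NC(=O)NC1c1ccoc1`: 2%

All three were tested in an assay on membranes from HEK293 cells for displacement of a labelled ligand from adenosine receptor A2b (Homo sapiens), read by scintillation counting, with a stated time of 30 min, tested at 1 uM; on this read-out higher numbers stand for more inhibition at the one concentration tested (going by the name of the read-out) and lower numbers for less inhibition. Compound 1 and compound 2 share one core and differ in a single place: methyl in place of hydrogen on a saturated chain carbon bound to an oxygen next to a carbonyl group and two saturated chain carbons. That change gave a number 21 percentage points lower from compound 1 to compound 2 (beyond the scatter), so the larger ester gives the lower number of the two on this read-out. Compound 3 carries a different core, an ethylcarbamoyl group in place of the ester together with a hydrogen on the ring nitrogen where compound 1 and compound 2 carry a methyl; the difference between the two cores is not broken down here. Compound 3 gives the lowest number of the three, beyond the scatter from both compound 2 and compound 1.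

Compound 4 `CC1=C(C(=O)NC(C)C)C(c2ccoc2)NC(=O)N1` has not yet been measured. It differs from compound 3 in one place: methyl in place of hydrogen on a saturated chain carbon bound to an amide-type nitrogen and a saturated chain carbon. Among the compounds with values here, this is the same kind of change as the one from compound 1 to compound 2, but not the same: there the added methyl sits on a saturated chain carbon bound to an oxygen next to a carbonyl group and two saturated chain carbons, here on a saturated chain carbon bound to an amide-type nitrogen and a saturated chain carbon. Because compound 3 already gives 2%, there is almost no room for a further drop of the size seen in a number 21 percentage points lower from compound 1 to compound 2 (beyond the scatter). Compound 4 is therefore expected to stay near the floor of this assay, with an estimated step of a number 1 percentage points higher from compound 3 to compound 4 (within the scatter). The estimate for compound 4 in this assay is 3%, between -5% and 12%.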

Compound 4, a percentage reported as inhibition, at one concentration (the size of the read-out at that concentration, not a potency): 3%
For compound 4 middle estimate and measured number coincide at the digits printed, and the stated range covers the measured number.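

In this assay the new step is a number 1 percentage points higher from compound 3 to compound 4 (within the scatter), so methyl in place of hydrogen on a saturated chain carbon bound to an amide-type nitrogen and a saturated chain carbon gives no difference that can be read on this core. Set beside the earlier step, the added methyl does not carry over in size from one core to the other: the same change on two cores in this assay, a number 21 percentage points lower (beyond the scatter) from compound 1 to compound 2 and a number 1 percentage points higher (within the scatter) from compound 3 to compound 4, 22 percentage points apart, beyond the scatter of two such steps

This does not show which feature of the two pairs sets the steps apart, since they differ in the carbon carrying the methyl, in ester against amide and in the group on the ring nitrogen, and with compound 3 at 2% a drop of the earlier size would have had almost no room to appear on the second core.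

The compounds shown leave open how the methyl change would read on a core that starts from a higher number, for example an ethylcarbamoyl or isopropylcarbamoyl group on the core of compound 1, with its methyl on the ring nitrogen. They also leave open whether a longer chain or a terminal amine on the amide nitrogen would give a number clear of the low end of this read-out.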